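The source may hold more compounds than are shown below. What is called first, only, known or untested is meant among the compounds shown, and "the series" means these compounds.

Measured compounds:
compound 1 `COc1cc2c(Oc3ccc(NC(=O)c4cn(-c5c(C)cccc5C)nn4)cc3F)ccnc2cc1OCCCN1CCC(C)CC1` — 4310 nM
compound 2 `COc1cc2c(Oc3ccc(NC(=O)c4cn(-c5ccc(F)c(F)c5)nn4)cc3F)ccnc2cc1OCCCN1CCC(C)CC1` — 1290 nM
compound 3 `COc1cc2c(Oc3ccc(NC(=O)c4cn(-c5c(C)cccc5C)nn4)cc3F)ccnc2cc1OCCCN1CCN(C)CC1` — "not determined" (no result reported)

All three compounds were tested in a functional assay on MKN-45 cells (Homo sapiens) for cytotoxicity, read by MTT assay, with a stated time of 72 h; on this read-out lower numbers stand for stronger inhibition and higher numbers for weaker inhibition. Compound 1 and compound 2 share a core and differ in one place: 3,4-difluorophenyl in place of 2,6-dimethylphenyl on an aromatic nitrogen. This change gave a 3.3-fold lower number from compound 1 to compound 2 (0.52 log units; beyond the scatter). Compound 3 carries the same group as compound 1 on the five-membered ring, but its core differs from that of compound 1 in one place: 4-methylpiperazin-1-yl in place of 4-methylpiperidin-1-yl on a saturated chain carbon, three bonds along the chain from an oxygen on an aromatic ring. Going by these compounds, for compound 3 no result was obtained in this assay, so its own position is unknown.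

Compound 4 `COc1cc2c(Oc3ccc(NC(=O)c4cn(-c5ccc(F)c(F)c5)nn4)cc3F)ccnc2cc1OCCCN1CCN(C)CC1` is not yet measured. It differs from compound 3 in one place: 3,4-difluorophenyl in place of 2,6-dimethylphenyl on an aromatic nitrogen. The surroundings of the change are described in exactly the same words as for the step from compound 1 to compound 2, so this is the same change made on the other core. Within the data shown here, with only one measured example of this change, and no value for compound 3, the estimate rests on compound 2 and on the assumption that the change in the core is small. For compound 4 an expected value of about 1500 nM is estimated, with a likely range from 500 nM to 5000 nM.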

Compound 4, half-maximal inhibitory concentration: 160 nM
For compound 4 the middle estimate is 9.4-fold (0.97 log units) above the measured one; measured number outside the range, below it.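

In this assay, putting 4-methylpiperazin-1-yl in place of 4-methylpiperidin-1-yl, with 3,4-difluorophenyl on the five-membered ring, gave an 8.1-fold lower number from compound 2 to compound 4 (0.91 log units; beyond the scatter) and so this difference between the cores is not small for this pair. Among these compounds, it does not show how the change from 2,6-dimethylphenyl to 3,4-difluorophenyl behaves on the second core: compound 3 has no result, so its step to compound 4 and its step from compound 1 cannot be read, and a 3.3-fold lower number from compound 1 to compound 2 (0.52 log units; beyond the scatter) remains the only measured example of that change. No measurement given here explains why the two cores differ.

Going by these compounds, whether the piperazine core keeps its lower number with 2,6-dimethylphenyl on the five-membered ring therefore stays open. Also open, on these data alone, is how the series would respond to morpholin-4-yl at the end of the chain, or to a longer chain between the oxygen and the ring at its end.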